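This account rests on a few compounds, and the source may have more. Where it says the series, first, only, none or still open, it means among the compounds named here.

Measured so far in a functional assay for inhibition, with Homo sapiens as the target, tested at 100 uM; a higher number here means a weaker inhibitor, a lower number a stronger inhibitor:
- Compound 1 `CCC1=Nc2c(OC)cccc2C(=O)C1`: > 100000 nM (a limit)
- Compound 2 `Cc1ccccc1-c1nc2c(Cl)cccc2c(=O)o1`: 13800 nM

Compound 1 has no numerical value on this read-out, since > 100000 nM is a limit. Among the measured compounds shown here, compound 2 supplies the only number so far, at 13800 nM, but it does not differ from compound 1 in one place, so it gives no measured step to build on.

The next compound, compound 3 `CCCCC1=Nc2c(OC)cccc2C(=O)C1`, has ethyl in place of hydrogen on a saturated chain carbon, two bonds along the chain from a carbon with a double bond to nitrogen. Cut one bond further out, the same difference reads ethyl to butyl.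

For the measured compounds named here, no measured pair shows what this change does in this assay. A modest step toward stronger inhibition is the expectation, and compound 3 may also report only a limit. The starting point for this expectation is the limit of compound 1, > 100000 nM. The estimated step is an at least 1.4-fold lower number from compound 1 to compound 3 (0.15 log units; that floor lies within the scatter). For compound 3, the expected value is 70000 nM, with an estimated range of 15000 nM to 200000 nM.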

Compound 3, half-maximal inhibitory concentration: > 100000 nM
Compound 3: no number, only a limit; the forecaster's own chance of this, stated with the estimate: 50%; middle value at least 1.4-fold (0.15 log units) away from the limit.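

In this assay, compound 3 gives only a limit, as compound 1 does, so no step can be read between compound 1 and compound 3: the limit of > 100000 nM in this assay, at which 2 of the 3 values shown sit.

The compounds shown leave open whether ethyl in place of hydrogen on this saturated chain carbon changes inhibition at all, and in which direction.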